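Piperidin-3-yl to piperidin-2-yl: an expected cytotoxicity step

The source may hold more compounds than are shown below. What is called first, only, known or untested is meant among the compounds shown, and "the series" means these compounds.

Compound 1 (`Cc1nc(C(NC(=O)C(=O)NC2CCCCCC2)C2CCCCN2)sc1CCO`): (60000 nM)
Compound 2 (`Cc1nc(C(NC(=O)C(=O)Nc2ccc(Cl)cc2)C2CCCNC2)sc1CCO`): (> 78500 nM)

In an ADME assay on MT2 cells (Homo sapiens) for cytotoxicity, read by XTT assay, with a stated time of 4 days (on this read-out higher numbers stand for lower toxicity in this test and lower numbers for higher toxicity in this test), compound 1 gives a measured number (60000 nM). Compound 2 has no number in this assay. Compound 2 is reported only as a limit of the assay (> 78500 nM).

Compound 3 (`Cc1nc(C(NC(=O)C(=O)Nc2ccc(Cl)cc2)C2CCCCN2)sc1CCO`) has the same atoms as compound 2, joined differently (piperidin-2-yl in place of piperidin-3-yl on a saturated chain carbon bound to an amide-type nitrogen and an aromatic carbon). In words, piperidin-2-yl stands in place of piperidin-3-yl on a saturated chain carbon bound to an amide-type nitrogen and an aromatic carbon. Within the data shown here, no measured pair of compounds shows this change, and its size in this assay has not been observed. Among the measured compounds shown here, the expectation therefore leans on compound 1 (60000 nM), the only true number available. No change beyond the usual scatter is expected, with a slight lean towards lower numbers, and the expected step is an at least 1.4-fold lower number from compound 2 to compound 3 (0.15 log units; that floor lies within the scatter) in this reading. Compound 3 is estimated at 55000 nM within an expected range from 22000 nM to 110000 nM for a single measurement.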

Compound 3, half-maximal cytotoxic concentration: > 62000 nM
Compound 3: a limit, no number (the forecaster's own chance of this, stated with the estimate: 35%); at least 1.1-fold (0.05 log units) between middle value and limit.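

In this assay compound 3 is reported only as a limit of the assay, > 62000 nM. With 4-chlorophenyl on the amide-type nitrogen, piperidin-2-yl therefore ends at a limit just as piperidin-3-yl does in compound 2, and the step between these two compounds cannot be read, because neither gives a number: the limit of > 62000 nM in this assay, at which 1 of the 3 values shown sits. Compound 3 also gives the first readable comparison with compound 1, where 4-chlorophenyl in place of cycloheptyl on an amide-type nitrogen, with piperidin-2-yl kept, gives an at least 1.0-fold higher number from compound 1 to compound 3 (0.01 log units; that floor lies within the scatter), so this change is not shown to separate the two compounds in this assay.

From the compounds shown here alone, how much higher the true values of compound 2 and compound 3 lie than their limits remains open, and so does the real size of the change from piperidin-3-yl to piperidin-2-yl. Going by these compounds, it is also open whether a pyrrolidine ring or an open-chain amine on the same saturated chain carbon would give a number in this assay rather than a limit.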